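The compounds below may be only part of what the source reports. "The series", "measured", "known", "first", "only" and "open" are said of these compounds alone.

Compounds measured so far:

Compound 1, `CN(C[C@H]1Cc2c(cccc2N2CCN(C3COC3)CC2)CN1)[C@H]1CCCc2cccnc21`, in a functional assay on CCRF-CEM cells for antagonist activity at C-X-C chemokine receptor type 4 (Homo sapiens), read by calcium flux, with stated times of 25 min and 90 s (a lower number here means a stronger inhibitor, a higher number a weaker inhibitor), gives 381 nM.
Compound 2, `CCN1CCN(c2cccc3c2C[C@H](CN(C)[C@H]2CCCc4cccnc42)NC3)CC1`, in this assay gives 13.8 nM.

Compound 2 stands with the lowest of the two numbers; its nearest neighbour is compound 1, and the step between them, a 28-fold lower number from compound 1 to compound 2 (1.44 log units; beyond the scatter), is the only one these data hold. Compound 3, `CN(C[C@H]1Cc2c(cccc2N2C[C@@H]3C[C@H]2CN3)CN1)[C@H]1CCCc2cccnc21`, carries a different change: a group of 7 heavy atoms (5 carbon, 2 nitrogen; 2 five-membered non-aromatic rings with 1 hetero atom each) in place of a group of 8 heavy atoms (6 carbon, 2 nitrogen; one six-membered non-aromatic ring with 2 hetero atoms), on an aromatic carbon. Here the whole six-membered ring is exchanged for a pair of fused five-membered rings bearing a hydrogen-bond donor, whereas the one measured step only swapped the substituent on the ring nitrogen. That step shows the group on this aromatic carbon matters greatly, but it does not show what a bridged bicyclic amine does there. The author therefore expects the number for compound 3 to move up from compound 2 by a 2.5-fold higher number from compound 2 to compound 3 (0.40 log units; beyond the scatter), a modest loss rather than a large one. The estimate for compound 3 in this assay is 35 nM, with a range of 8 nM to 150 nM.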

Compound 3, half-maximal inhibitory concentration: 146 nM
Compound 3: middle estimate off by 4.2-fold (0.62 log units), on the low side; the measured number falls inside the stated range.
By their numbers in this assay, from the lowest: compound 2; then compound 3; then compound 1.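

In this assay, the earlier step had changed only the substituent on the ring nitrogen, whereas exchanging the whole 4-ethylpiperazin-1-yl group for the group with two five-membered non-aromatic rings, which carries a hydrogen-bond donor, also gives a large loss (an 11-fold higher number from compound 2 to compound 3 (1.02 log units; beyond the scatter)). The same group compares better with the oxetane-bearing group of compound 1, although this gain is only modest (a 2.6-fold lower number from compound 1 to compound 3 (0.42 log units; beyond the scatter)), so the three compounds show that this aromatic carbon tolerates a change of ring but that neither the new group nor the oxetane-bearing one matches the 4-ethylpiperazin-1-yl group of compound 2. Nothing given here explains these differences.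

On these data alone, the change from compound 2 to compound 3 alters the ring system, the ethyl group and the donor count in a single step, so the share of each in the loss remains unknown. A plain piperazin-1-yl group or a 4-methylpiperazin-1-yl group on this aromatic carbon would help separate these contributions, and an ethyl group on the ring nitrogen of the two-ring group would test whether that substituent restores the lower number.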